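Aryl versus alkyl substituent on the shared core: permeability notes

The source may hold more compounds than are shown below. What is called first, only, known or untested is meant among the compounds shown, and "the series" means these compounds.

Measured so far:
compound 1 `Fc1ccc(-c2ccc3c(NCCCNCc4ccco4)ccnc3c2)cc1`: 237 10^-6 cm/s
compound 2 `Cc1cc(C)cc(Cc2ccc3c(NCCCNCc4ccco4)ccnc3c2)c1`: 23 10^-6 cm/s
compound 3 `CC(C)CCc1ccc2c(NCCCNCc3ccco3)ccnc2c1`: 23 10^-6 cm/s

In an ADME assay for permeability, using PAMPA, with a stated time of 30 min, at pH 7.4 (a higher number here means that the compound crosses the layer faster, a lower number that the compound crosses the layer more slowly), compound 1 gives 237 10^-6 cm/s, compound 2 gives 23 10^-6 cm/s and compound 3 gives 23 10^-6 cm/s. Compound 3 stands level with compound 2, the two together at the low end of the three; compound 1 stands apart, with a 10-fold lower number from compound 1 to compound 3 (1.01 log units; beyond the scatter) and a 10-fold lower number from compound 1 to compound 2 (1.01 log units; beyond the scatter). Between the two alkyl-type substituents there is no change at the digits printed from compound 2 to compound 3 (within the scatter).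

Compound 4 `COc1ccc(-c2ccc3c(NCCCNCc4ccco4)ccnc3c2)cc1` is not yet measured in this assay. The change from compound 3 is 4-methoxyphenyl in place of isopentyl on an aromatic carbon. Among the compounds with values here, the one measured step that bears on it is the reverse of the step from compound 1 to compound 3, where an aromatic ring in place of an aliphatic chain in the same place gave a large difference. Within the data shown here, the methoxy group in place of fluorine on that ring has no measured counterpart here. A rise of similar size is therefore expected, as a 6.5-fold higher number from compound 3 to compound 4 (0.81 log units; beyond the scatter). Compound 4 is expected to give about 150 10^-6 cm/s, within 50 10^-6 cm/s to 400 10^-6 cm/s.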

Compound 4, apparent permeability: 237 10^-6 cm/s
Beside the measured number, compound 4's estimate is 1.6-fold (0.20 log units) below it; measured number inside the range.
By their numbers in this assay, from the lowest: compounds 2 and 3 (each within the scatter of the next); then compounds 1 and 4 (each within the scatter of the next).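

In this assay the change to 4-methoxyphenyl repeats the gap first seen with 4-fluorophenyl: a 10-fold higher number from compound 3 to compound 4 (1.01 log units; beyond the scatter) and a 10-fold higher number from compound 2 to compound 4 (1.01 log units; beyond the scatter) mark it on the same aromatic carbon. Across the four compounds, a phenyl ring bound directly to that carbon goes with the high numbers in compounds 1 and 4, while compounds 2 and 3, with a saturated carbon there, hold the low numbers; none of the four goes against this. Within the data shown here, on the phenyl ring itself there is no change at the digits printed from compound 1 to compound 4 (within the scatter) for methoxy in place of fluoro, the first measured change on that ring.

Going by these compounds, whether this level holds with an amine or a carboxylic acid on the phenyl ring, or with a pyridine ring in its place, stays open. No evidence on hand accounts for the gap between the two pairs.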